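Bromo in place of chloro across two pairs

This account rests on a few compounds, and the source may have more. Where it says the series, first, only, none or still open, it means among the compounds named here.

Compound 1 `O=C(CSc1nc(Nc2ccccc2)c2ccccc2n1)Nc1ccccc1Cl` and compound 2 `O=C(CSc1nc(Nc2ccccc2)c2ccccc2n1)Nc1ccccc1Br` share one core; compound 3 `C=CC(=O)Nc1cccc(NC(=O)CSc2nc(Nc3cccc(Cl)c3)c3ccccc3n2)c1` and the unmeasured compound 4 `C=CC(=O)Nc1cccc(NC(=O)CSc2nc(Nc3cccc(Br)c3)c3ccccc3n2)c1` share another, and the difference between the two cores is not broken down here. In a functional assay on MDA-MB-231 cells (Homo sapiens) for inhibition, read by MTT assay, with a stated time of 72 h (a higher number here means a weaker inhibitor, a lower number a stronger inhibitor), compound 1 gives 24400 nM, compound 2 gives 14100 nM, and compound 3 gives 16300 nM. The change from compound 1 to compound 2 is bromo in place of chloro on an aromatic carbon and produced a step of a 1.7-fold lower number from compound 1 to compound 2 (0.24 log units; within the scatter). From compound 3 to compound 4 the change is bromo in place of chloro on an aromatic carbon: the same kind of change, though here the place is meta to a large group where in the first pair it was ortho to a large group. A step of about a 1.4-fold lower number from compound 3 to compound 4 (0.13 log units; within the scatter) is expected, resting on the earlier step of a 1.7-fold lower number from compound 1 to compound 2 (0.24 log units; within the scatter). Compound 4 is therefore estimated at 12000 nM, with a range from 6000 nM to 28000 nM.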

Compound 4, half-maximal inhibitory concentration: 19400 nM
Beside the measured number, compound 4's estimate is 1.6-fold (0.21 log units) below it; the range from low to high includes it.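

In this assay, bromo in place of chloro on the core of compound 3 gives a 1.2-fold higher number from compound 3 to compound 4 (0.08 log units; within the scatter), so on this core, as on the core of compound 1, the step stays within the scatter. The two steps cannot be told apart: the same change on two cores in this assay, a 1.7-fold lower number (0.24 log units; within the scatter) from compound 1 to compound 2 and a 1.2-fold higher number (0.08 log units; within the scatter) from compound 3 to compound 4, 2.1-fold (0.31 log units) apart, within the scatter of two such steps. This shows no detectable dependence of the change on the core in these two pairs, but it does not show that the two cores respond alike, as both steps are small and the place of the halogen also differs between the pairs.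

The compounds shown leave open how a fluoro, methoxy or amino group in that place would compare with chloro and bromo. They also leave open which part of the difference between the two cores bears on the read-out.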